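The source may hold more compounds than are shown below. What is called first, only, known or untested is meant among the compounds shown, and "the series" means these compounds.

Of the compounds shown here, three sharing one core have been measured in an assay on membranes from brain for displacement of a labelled ligand from Neuronal acetylcholine receptor; alpha4/beta2 (Rattus norvegicus); a higher number here means a weaker inhibitor, a lower number a stronger inhibitor. Compound 1 `Cc1ncccc1OC[C@@H]1CCCN1C` gives 22.9 nM, and compound 2 `CN1CCC[C@H]1COc1cnccc1Br` gives 28 nM. Compound 3 `CN1CCC[C@H]1COc1cncc(Cl)c1` gives 0.6 nM, the lowest number of the three and the strongest binder among them, since its distance from each of the other two lies beyond the usual scatter. Compound 4 `CCCCCCc1cncc(OC[C@@H]2CCCN2C)c1` has not yet been measured. It differs from compound 3 in one place: hexyl in place of chloro on an aromatic carbon. Within the data shown here, no measured pair shows a change of this kind, so nothing can be read off directly. A weakening of binding is nevertheless expected, of the size given by a 50-fold higher number from compound 3 to compound 4 (1.70 log units; beyond the scatter). For compound 4 the estimated value in this assay is 30 nM, within a range from 5 nM to 200 nM.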

Compound 4, inhibition constant: 0.32 nM
The estimate for compound 4 lay 94-fold (1.97 log units) above the measured number, and the stated range ends above it.
By their numbers in this assay, from the lowest: compounds 4 and 3 (each within the scatter of the next); then compounds 1 and 2 (each within the scatter of the next).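

In this assay, hexyl in place of chloro on this aromatic carbon gives a 1.9-fold lower number from compound 3 to compound 4 (0.27 log units; within the scatter), so the two compounds cannot be told apart. Among these compounds, this aromatic carbon can therefore carry a chain of six carbons instead of a single chlorine with binding kept in the same range, which the earlier compounds gave no way of seeing. Nothing available says why hexyl is accepted here. On these data alone, whether a longer chain would be accepted at this aromatic carbon remains open. So does whether an amine or a carboxylic acid would be.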